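The compounds below may be only part of what the source reports. "The series", "measured", "known", "first", "only" and "open" are said of these compounds alone.

Compound 1 `CC(=O)N1CC2CC(C1)N2` is the simplest member of this set, and in an assay on SH-EP1 cells for agonist activity at Neuronal acetylcholine receptor; alpha4/beta2 (Homo sapiens), read by FLIPR and calcium flux (on this read-out higher numbers stand for larger maximal responses and lower numbers for smaller maximal responses), compound 1 gives 94%. Replacing the methyl on the carbonyl carbon with a small ring raises the response: compound 2 `O=C([C@H]1C[C@H]1F)N1CC2CC(C1)N2` gives 110% in this assay, and compound 3 `C[C@@H]1C[C@H]1C(=O)N1CC2CC(C1)N2` gives 110%. The two steps from the parent are alike, a number 16 percentage points higher from compound 1 to compound 2 (beyond the scatter) and a number 16 percentage points higher from compound 1 to compound 3 (beyond the scatter), while between the two ring-bearing compounds no change at the digits printed from compound 2 to compound 3 (within the scatter). Compound 3 therefore stands level with compound 2 at the digits shown, the two together at the top of the three numbers, with compound 1 the furthest away.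

Compound 4 `C[C@H]1C[C@@H]1C(=O)N1CC2CC(C1)N2` is the next step from compound 3. The change is the two compounds have the same atoms and bonds; at least one stereo element is drawn with a configuration in one of them and without one in the other: 2 of 4 stereo elements differ; a stereocentre at a saturated ring carbon is drawn R in compound 3 and S in compound 4; a stereocentre at a saturated ring carbon is drawn R in compound 3 and S in compound 4. Within the data shown here, none of the measured steps bears directly on this: each of them exchanged the group on the carbonyl carbon and left the stereocentres untouched, so the data give no measured step with which to compare a change of configuration alone. With the same atoms and bonds present, the plain expectation is a number 5 percentage points lower from compound 3 to compound 4 (within the scatter), though the lack of any comparable step leaves this uncertain. Compound 4 is thus expected to give about 105% in this assay, within a range of 85% to 120%.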

Compound 4, largest response reached (Emax), in percent of the reference or control that the assay uses: 67%
Beside the measured number, compound 4's estimate is 38 percentage points above it, outside the stated range (below it).
By their numbers in this assay, from the lowest: compound 4; then compound 1; then compounds 2 and 3 (each within the scatter of the next).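

Earlier, both ring groups on the carbonyl carbon had raised the response above compound 1, so the ring itself seemed to be enough. In this assay, the same atoms and bonds now give a clear fall when only the drawn configuration of the 2-methylcyclopropyl group changes, with a number 43 percentage points lower from compound 3 to compound 4 (beyond the scatter). The group can therefore fall on either side of the acetyl parent, with a number 27 percentage points lower from compound 1 to compound 4 (beyond the scatter) and, against the fluorinated compound, a number 43 percentage points lower from compound 2 to compound 4 (beyond the scatter), so in these compounds the direction of the change at this position depends on the ring's configuration as well as on its substituent. One point limits how exactly this step can be assigned to a configuration: the fact that one of compounds 3 and 4 is drawn with a defined configuration and the other without, at the place where they differ.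

The compounds shown leave open whether the 2-fluorocyclopropyl group of compound 2 would respond to the same change of configuration as the 2-methylcyclopropyl group does. They also leave open how an unsubstituted cyclopropyl, a 2-ethylcyclopropyl or a cyclobutyl group on the carbonyl carbon would behave on this read-out.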